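The compounds below may be only part of what the source reports. "The series", "measured", "known", "first", "only" and "open" are said of these compounds alone.

Measured so far:
- Compound 1 `Cc1ccc(C(=O)Nc2cc3nc(C4CCCCC4)[nH]c3cc2N2CCCC2)cc1` gives > 100 ug/mL in an ADME assay on Vero cells (Chlorocebus sabaeus) for cytotoxicity, read by resazurin assay, with a stated time of 3 days; on this read-out lower numbers stand for stronger inhibition and higher numbers for weaker inhibition; this value is a limit of the assay.
- Compound 2 `CCN(CC)c1cc2[nH]c(C3CCCCC3)nc2cc1NC(=O)c1ccc(OC(F)(F)F)cc1` gives > 100 ug/mL in this assay; this too is a limit.
- Compound 3 `CN(C)c1cc2[nH]c(C3CCCCC3)nc2cc1NC(=O)c1ccc(OC(F)(F)F)cc1` gives > 100 ug/mL in this assay; again a limit.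

Compound 2 therefore stands at the limit itself, together with the other two measured compounds, as the limit of > 100 ug/mL in this assay, at which 3 of the 3 values shown sit, records. Among the compounds with values here, the only measured step between compounds that differ in one place, a step that the two limits leave unreadable from compound 2 to compound 3, cannot be read as a size, since both of its values are limits.

Compound 4 `C=Cc1cccc(C(=O)Nc2cc3nc(C4CCCCC4)[nH]c3cc2N(CC)CC)c1` is not yet measured. It differs from compound 2 in one place: 3-vinylphenyl in place of 4-(trifluoromethoxy)phenyl on a carbonyl carbon. Within the data shown here, no measured step involves a change on the carbonyl carbon, so none bears directly on this one; what the data show is only that every compound so far, whatever its substituent, sat at the limit of this assay.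

On that basis the step of a number no higher from compound 2 to compound 4 (the limit leaves the size open) is expected to be small or absent, and compound 4 is estimated at 100 ug/mL, within a range from 50 ug/mL to 200 ug/mL, most likely reported as a limit once more.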

Compound 4, half-maximal inhibitory concentration: > 100 ug/mL
Compound 4: a limit, no number; the forecaster's own chance of this, stated with the estimate: 80%; the middle value sits exactly at the limit.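

Compound 2 and compound 4 are both recorded only as limits in this assay, so the change from 4-(trifluoromethoxy)phenyl to 3-vinylphenyl cannot be read as a size. All the results shown stand at one point: the limit of > 100 ug/mL in this assay, at which 4 of the 4 values shown sit.

As far as these compounds go, what stays open is how far past that limit each compound lies, and whether any structural change would give a readable number in this assay.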